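Benzyloxy for phenoxy on the biaryl ether series

The source may report more compounds than this note shows. Statements on the series, on what has been measured and on what is new or still open speak of the compounds shown alone.

Compound 1 `O=C(O)CCCOc1ccc(-c2cccc(Oc3ccccc3)c2)cc1` is the parent of this short set. In a functional assay on isolated protein for agonist activity at Free fatty acid receptor 1 (Homo sapiens), read by HTRF and inositol phosphate accumulation, with a stated time of 60 min (on this read-out lower numbers stand for an effect already at smaller amounts and higher numbers for an effect only at larger amounts of compound), compound 1 gives 6800 nM, the higher of the two numbers recorded. Compound 2 `O=C(O)CCCOc1ccc(-c2cc(Oc3ccccc3)ccc2F)cc1` carries a fluoro in place of hydrogen on an aromatic carbon and gives 3590 nM in this assay, so the step of a 1.9-fold lower number from compound 1 to compound 2 (0.28 log units; within the scatter) stays inside the scatter. Compound 3 `O=C(O)CCCOc1ccc(-c2cc(Oc3cccnc3)ccc2Cl)cc1` returns only a limit in this assay, > 9950 nM, which is the limit (the limit of > 9950 nM in this assay, at which 1 of the 3 values shown sits).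

Compound 4 `O=C(O)CCCOc1ccc(-c2cccc(OCc3ccccc3)c2)cc1` differs from compound 1 by benzyl in place of phenyl on an oxygen on an aromatic ring. Within the data shown here, no measured step in this set moves the phenoxy group itself; the one step recorded concerns a ring hydrogen and is within the scatter, so there is no measured basis for a shift in this assay beyond the scatter in either direction. Compound 4 is therefore expected to sit close to compound 1, with a step of a 1.1-fold lower number from compound 1 to compound 4 (0.05 log units; within the scatter), and its estimated value in this assay is 6000 nM, between 2000 nM and 20000 nM.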

Compound 4, half-maximal effective concentration: > 9950 nM
Compound 4: only a limit was reported; the forecaster's own chance of this, stated with the estimate: 25%; at least 1.6-fold (0.21 log units) between middle value and limit.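

In this assay, among these compounds, the change from phenoxy to benzyloxy is the only step in this set that alters the ether group itself, and it reads as an at least 1.4-fold higher number from compound 1 to compound 4 (0.16 log units; that floor lies within the scatter). Going by these compounds, compound 4 is reported only as a limit, so the size of this step stays unknown, and its floor alone does not separate compound 4 from compound 1. What is new at this position is that the benzyl group gives a second compound at the limit: the limit of > 9950 nM in this assay, at which 2 of the 4 values shown sit.

On these data alone, the true value of compound 4 remains open, as a limit cannot supply it. Also open, as far as these compounds go, are how a phenethyl group on that oxygen, or an amine in place of that oxygen, would read in this assay, and whether the fluoro substitution of compound 2 would behave the same way alongside benzyloxy.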